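Series notes: amine ring size on the amide side chain

A few compounds are considered here, and "the series" means these few. Any claim that something is new, unique, unknown or untested is made for them only; others in the source may bear on it.

All values come from a functional assay on A549 cells (Homo sapiens) for inhibition; a lower number here means a stronger inhibitor, a higher number a weaker inhibitor.
Compound 1 `O=C(CC(CC(=O)NC1Cc2ccccc2C1)c1ccc(Cl)cc1)NCCN1CCCCC1`: 28000 nM
Compound 2 `O=C(CC(CC(=O)NC1Cc2ccccc2C1)c1ccc(Cl)cc1)NCCN1CCCC1`: 50900 nM
Compound 3 `CCN(C(=O)CC(CC(=O)NCCN1CCCC1)c1ccccc1)C1Cc2ccccc2C1`: > 100000 nM, which is a limit of the assay and not a number.

Compound 2 and compound 1 differ by one change, (piperidin-1-yl in place of pyrrolidin-1-yl on a saturated chain carbon, two bonds along the chain from an amide-type nitrogen), giving the step of a 1.8-fold lower number from compound 2 to compound 1 (0.26 log units; within the scatter). The difference between the core of compound 3 and the core of compound 2 is not broken down here. Compound 4 `CCN(C(=O)CC(CC(=O)NCCN1CCCCC1)c1ccccc1)C1Cc2ccccc2C1` is not yet measured; it carries the same change on the core of compound 3, (piperidin-1-yl in place of pyrrolidin-1-yl on a saturated chain carbon, two bonds along the chain from an amide-type nitrogen). Compound 3 sits at the limit of > 100000 nM in this assay, at which 1 of the 3 values shown sits. The expected step is an at least 1.1-fold lower number from compound 3 to compound 4 (0.04 log units; that floor lies within the scatter), resting on the measured step of a 1.8-fold lower number from compound 2 to compound 1 (0.26 log units; within the scatter) being within the scatter. For compound 4 the estimated value in this assay is 90000 nM, with a likely range from 40000 nM to 200000 nM, and most likely again only a limit is reported.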

Compound 4, half-maximal inhibitory concentration: 84500 nM
Compound 4: middle estimate off by 1.1-fold (0.03 log units), on the high side; low and high end bracket the measured number.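

On the core of compound 3, piperidin-1-yl in place of pyrrolidin-1-yl gives an at least 1.1-fold lower number from compound 3 to compound 4 (0.07 log units; that floor lies within the scatter) in this assay. The entry for compound 3 is a limit of the assay and not a number: the limit of > 100000 nM in this assay, at which 1 of the 4 values shown sits. The step on the core of compound 2 lies within the scatter and the step on the core of compound 3 is only a floor, so the data show neither that the change carries over unaltered nor that it acts differently on the two cores: the same change on two cores in this assay, a 1.8-fold lower number (0.26 log units; within the scatter) from compound 2 to compound 1 and an at least 1.1-fold lower number (0.07 log units; that floor lies within the scatter) from compound 3 to compound 4; the limit leaves it open whether they differ.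

Still open, on these data alone, is whether a morpholine or a dimethylamino group in place of these rings, or a longer chain to the amine, would give a step beyond the scatter.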